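The compounds below may be only part of what the source reports. "The series", "measured", "known", "first", "only" and "open" are said of these compounds alone.

Measured so far:
- compound 1, `COc1nc2ccc(Br)cc2cc1C(c1ccccc1)n1cc(-c2ccc(Br)cc2)nn1`: 10.4%
- compound 2, `CCCCCCc1cn(C(c2ccccc2)c2cc3cc(Br)ccc3nc2OC)nn1`: 6.08%
- compound 3, `COc1nc2ccc(Br)cc2cc1C(c1ccccc1)n1cc(-c2ccc(OC(F)(F)F)cc2)nn1`: 11.7%

In an ADME assay on PANC-1 cells (Homo sapiens) for cytotoxicity, read by sulforhodamine B assay, with a stated time of 48 h, tested at 10 uM (a higher number here means more inhibition at the concentration tested (going by the name of the read-out), a lower number less inhibition), compound 2 gives 6.08%, the smallest of the three numbers, yet neither gap separates it from the others: the step of a number 4.3 percentage points lower from compound 1 to compound 2 (within the scatter) and the step of a number 5.6 percentage points higher from compound 2 to compound 3 (within the scatter) both stay within the scatter, so the three compounds cannot be told apart on these data.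

Compound 4, `COc1nc2ccc(Br)cc2cc1C(c1ccccc1)n1cc(-c2ccccc2C(F)(F)F)nn1`, differs from compound 2 in one place: 2-(trifluoromethyl)phenyl in place of hexyl on an aromatic carbon. Among the compounds with values here, two measured steps touch the same place. Replacing an aryl group on that carbon by hexyl gave a number 4.3 percentage points lower from compound 1 to compound 2 (within the scatter), and putting an aryl group back in place of hexyl gave a number 5.6 percentage points higher from compound 2 to compound 3 (within the scatter), both within the scatter. Swapping hexyl for the 2-(trifluoromethyl)phenyl group is therefore expected to move this assay by a step of about a number 3.9 percentage points higher from compound 2 to compound 4 (within the scatter), upward if anything, but not clearly beyond the scatter. Compound 4 is estimated at 10%, with a range from 3% to 18%.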

Compound 4, a percentage reported as inhibition, at one concentration (the size of the read-out at that concentration, not a potency): 11.4%
Compound 4: the middle estimate sits 1.4 percentage points below what was measured; low and high end bracket the measured number.
By their numbers in this assay, from the lowest: compounds 2, 1, 4 and 3 (each within the scatter of the next).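

With 2-(trifluoromethyl)phenyl on this carbon of the five-membered ring, this assay gives a number 5.3 percentage points higher from compound 2 to compound 4 (within the scatter) against the hexyl chain, and comparison with the two other aryl groups gives a number 0.3 percentage points lower from compound 3 to compound 4 (within the scatter) and a number 1 percentage points higher from compound 1 to compound 4 (within the scatter). Within the data shown here, three different aryl groups and one open chain at this place have now been compared, and no step among them separates two compounds, so this assay does not tell any of the four apart. No measurement is available that would explain this result.

The compounds shown leave open whether a group of a different kind on this carbon, such as an amine or a carboxylic acid, would stand clearly apart from these four. From the compounds shown here alone, all four also keep the rest of the shared core unchanged, so the effect of a change elsewhere remains unknown.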